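A Methyl Placed Differently on the Same Aromatic Ring

The compounds below may be only part of what the source reports. "The series", "measured", "known", "first", "only" and "open" are said of these compounds alone.

Compound 1 `N/C(=N\NC(=S)N1CCCCCC1)c1ccccn1`, compound 2 `Cc1cccc(/C(N)=N/NC(=S)N2CCSCC2)n1` and compound 3 `N/C(=N\NC(=S)N1CCSCC1)c1ccccn1` have been run in a functional assay on HeLa cells (Homo sapiens) for cytotoxicity, read by MTT assay, with a stated time of 72 h, tested at 1 uM; a higher number here means more inhibition of growth at the concentration tested, a lower number less inhibition of growth. Compound 1 gives 21.3%, compound 3 gives 25.1% and compound 2 gives 46.5%. The change from compound 3 to compound 2 is methyl in place of hydrogen on an aromatic carbon, and a number 21.4 percentage points higher from compound 3 to compound 2 (beyond the scatter). The difference between the cores of compound 1 and compound 3 is not broken down here. Compound 4 `Cc1ccnc(/C(N)=N/NC(=S)N2CCCCCC2)c1` is not yet measured; it differs from compound 1 by methyl in place of hydrogen on an aromatic carbon. This is the same kind of change, but the surroundings differ: in compound 2 the methyl is next to the ring nitrogen, in compound 4 it is opposite the ring nitrogen. The expected step is a number 10.7 percentage points higher from compound 1 to compound 4 (beyond the scatter), smaller than the measured one because that rests on a single step, a number 21.4 percentage points higher from compound 3 to compound 2 (beyond the scatter), at a different place. Compound 4 is estimated at 32%, between 15% and 50%.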

Compound 4, percent growth inhibition at one concentration: 43.2%
Compound 4: middle estimate off by 11.2 percentage points, on the low side, within the range that was stated.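

In this assay, methyl in place of hydrogen on the core of compound 1 gives a number 21.9 percentage points higher from compound 1 to compound 4 (beyond the scatter). Set beside the earlier step, the change carries over between the two cores at about the same size, although the methyl stands at a different place on the ring in each pair: the same change on two cores in this assay, a number 21.4 percentage points higher (beyond the scatter) from compound 3 to compound 2 and a number 21.9 percentage points higher (beyond the scatter) from compound 1 to compound 4, 0.5 percentage points apart, within the scatter of two such steps. For the compounds shown here, this rests on only two pairs, and core and place change together, so it does not show that the step would hold on further cores or separate the effect of one from the other.

The compounds shown leave open whether both places give the same step on one and the same core. They also leave open whether an ethyl, a methoxy or an amine at these places would follow the methyl.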